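The source may hold more compounds than are shown below. What is called first, only, known or untested is meant among the compounds shown, and "the series" means these compounds.

Of the compounds shown here, three have been measured in an assay on HEK293 cells for positive allosteric modulation of metabotropic glutamate receptor 3 (Rattus norvegicus), read by thallium flux, with a stated time of 2.5 min; on this read-out lower numbers stand for smaller maximal responses and higher numbers for larger maximal responses. Compound 1 `Cc1c(OCCCCOCOc2ccc(C(=O)O)cc2)ccc(C(=O)CC2CCCC2)c1O` gives 46.9% in this assay. Compound 2 `COc1ccc(C(=O)O)cc1OCCCCOc1ccc(C(=O)CC2CCCC2)c(O)c1C` gives 67.6% in this assay, and compound 3 `Cc1c(OCCCCOc2ccc(C(=O)O)cc2F)ccc(C(=O)CC2CCCC2)c1O` gives 31.2% in this assay. Among these three numbers compound 3 stands lowest: the step of a number 15.7 percentage points lower from compound 1 to compound 3 (beyond the scatter) and the step of a number 36.4 percentage points lower from compound 2 to compound 3 (beyond the scatter) both end at compound 3, while the step of a number 20.7 percentage points higher from compound 1 to compound 2 (beyond the scatter) places compound 2 at the top.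

Compound 4 `Cc1ccc(C(=O)O)cc1OCCCCOc1ccc(C(=O)CC2CCCC2)c(O)c1C` has not yet been measured. It differs from compound 3 in one place: 5-carboxy-2-methylphenyl in place of 4-carboxy-2-fluorophenyl on an oxygen on a saturated carbon. The measured step that bears most directly on this change is a number 36.4 percentage points lower from compound 2 to compound 3 (beyond the scatter). That step too exchanges a 5-carboxy-2-methoxyphenyl for the 4-carboxy-2-fluorophenyl, only in the opposite direction. Among the compounds with values here, compound 4 carries a 5-carboxy-2-methylphenyl rather than the methoxy variant, and no measured pair shows methyl against methoxy at this place, so the exact level remains open. Reversing the large fall seen in that step is nevertheless expected to raise the maximal response well beyond the scatter; compound 4 is expected to show the step of a number 28.8 percentage points higher from compound 3 to compound 4 (beyond the scatter) in this assay. Compound 4 is estimated at 60%, within a range from 42% to 78%.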

Compound 4, largest response reached (reported as percent of maximum), in percent of the reference or control that the assay uses: 26.9%
For compound 4 the middle estimate is 33.1 percentage points above the measured one, and the stated range ends above it.
By their numbers in this assay, from the lowest: compounds 4 and 3 (each within the scatter of the next); then compound 1; then compound 2.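

In this assay, putting 5-carboxy-2-methylphenyl in place of 4-carboxy-2-fluorophenyl on an oxygen on a saturated carbon gives a number 4.3 percentage points lower from compound 3 to compound 4 (within the scatter), so these two groups cannot be told apart here, and the large gap seen earlier between the 5-carboxy-2-methoxyphenyl and 4-carboxy-2-fluorophenyl groups does not carry over to every 5-carboxy-substituted phenyl. Within the data shown here, the first direct comparison of methyl with methoxy on this aromatic carbon gives a number 40.7 percentage points lower from compound 2 to compound 4 (beyond the scatter), which ties the high response of compound 2 to its methoxy group rather than to the 5-carboxyphenyl arrangement alone, while the comparison with the (4-carboxyphenoxy)methyl group gives a number 20 percentage points lower from compound 1 to compound 4 (beyond the scatter). Nothing available explains why a methoxy and a methyl group should differ so sharply at this place.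

The compounds shown leave open how an ethoxy group, a hydroxyl group or a chlorine on the same aromatic carbon would compare with methoxy. Among these compounds, they also leave open whether 4-carboxy-2-methoxyphenyl would keep the response of compound 2, since no pair here separates the place of the carboxylic acid from the group that accompanies it.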